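Methyl on the Aromatic Nitrogen of Compound 3

The compounds below may be only part of what the source reports. "The series", "measured", "known", "first", "only" and "open" are said of these compounds alone.

Compound 1 `c1ccc(-c2nnc(-c3c[nH]c4ccccc34)o2)cc1`: in a functional assay on LNCaP cells (Homo sapiens) for cytotoxicity, read by MTT assay (a lower number here means a stronger inhibitor, a higher number a weaker inhibitor), compound 1 reaches only the limit > 1000000 nM.
Compound 2 `COc1ccc(-c2nnc(-c3c[nH]c4ccccc34)o2)cc1OC`: in this assay compound 2 likewise stops at the limit > 1000000 nM.
Compound 3 `COc1cc(-c2nnc(-c3c[nH]c4ccccc34)o2)ccc1OCc1ccccc1`: in this assay compound 3 also stops at the limit > 1000000 nM.

Compound 3 therefore stands nowhere on a scale of numbers: its value is a limit of the assay, and the two other values shown are limits as well, all three sitting at the limit of > 1000000 nM in this assay, at which 3 of the 3 values shown sit. Within the data shown here, the single measured step between compounds that differ in one place, a step that the two limits leave unreadable from compound 2 to compound 3, cannot be read because the limit of > 1000000 nM in this assay, at which 3 of the 3 values shown sit, holds both of its ends.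

Compound 4 `COc1cc(-c2nnc(-c3cn(C)c4ccccc34)o2)ccc1OCc1ccccc1` differs from compound 3 by methyl in place of hydrogen on an aromatic nitrogen. Among the measured compounds shown here, no measured step bears on this change: the only step available is unreadable, and none of the three compounds has given a number. Nothing in the data can therefore set a size or a direction for the step in this assay, and the most that can be said is that a further limit is the likeliest outcome.

Compound 4 is accordingly expected to give about 2000000 nM, within 300000 nM to 10000000 nM, most probably again reported only as a limit. The step that the limit leaves unreadable from compound 3 to compound 4 is thus expected to be none beyond the scatter.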

Compound 4, half-maximal inhibitory concentration: > 1000000 nM
Compound 4: no number, only a limit (the forecaster's own chance of this, stated with the estimate: 80%); the middle value lies beyond the limit too.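

The step between compound 3 and compound 4 cannot be read, because both of its ends are limits rather than numbers: the limit of > 1000000 nM in this assay, at which 4 of the 4 values shown sit. The compounds shown leave open whether methyl in place of hydrogen on the aromatic nitrogen changes the result in this assay, and what number, if any, these four compounds would give there.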